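Bromo to chloro on the N-aryl group

The source may hold more compounds than are shown below. What is called first, only, known or untested is meant among the compounds shown, and "the series" means these compounds.

Compound 1 `N#Cc1cc(-c2ccccc2)n(-c2ccccn2)c1N` gives 32000 nM
Compound 2 `N#Cc1cc(-c2ccccc2)n(-c2ccncc2)c1N` gives 10700 nM
Compound 3 `N#Cc1cc(-c2ccccc2)n(-c2ccc(Br)cc2)c1N` gives 4600 nM

In a functional assay on A549 cells (Homo sapiens) for cytotoxicity, read by resazurin assay, with a stated time of 72 h (on this read-out lower numbers stand for stronger inhibition and higher numbers for weaker inhibition), compound 3 has the lowest number of the three, and compound 2 is its nearest neighbour. The next compound to consider is compound 4 `N#Cc1cc(-c2ccccc2)n(-c2ccc(Cl)cc2)c1N`, which differs from compound 3 by a single exchange: chloro in place of bromo on an aromatic carbon. This is chloro in place of bromo on an aromatic carbon, para to a large group.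

Among the compounds with values here, three measured steps bear on this only indirectly, since each replaces the whole group on the aromatic nitrogen: a 3.0-fold lower number from compound 1 to compound 2 (0.48 log units; beyond the scatter), a 7.0-fold lower number from compound 1 to compound 3 (0.84 log units; beyond the scatter) and a 2.3-fold lower number from compound 2 to compound 3 (0.37 log units; beyond the scatter). All are modest, though beyond the scatter. Within the data shown here, none of them exchanges bromo for chloro, so the data contain no direct precedent. The change in compound 4 is far smaller than those replacements, as the 4-chlorophenyl group stays in the place of the 4-bromophenyl group. No step beyond the scatter is therefore expected in this assay. The expected step is a 1.2-fold higher number from compound 3 to compound 4 (0.08 log units; within the scatter). For compound 4 the estimated value is 5500 nM, with an expected range of 2600 nM to 11500 nM.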

Compound 4, half-maximal inhibitory concentration: 7700 nM
The estimate for compound 4 lay 1.4-fold (0.15 log units) below the measured number; the range from low to high includes it.
By their numbers in this assay, from the lowest: compounds 3, 4 and 2 (each within the scatter of the next, the first and the last beyond it); then compound 1.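

In this assay, within the data shown here, the exchange of 4-bromophenyl for 4-chlorophenyl gives a 1.7-fold higher number from compound 3 to compound 4 (0.22 log units; within the scatter) as the first direct reading of this change, so bromo and chloro are not separated at this place, on an aromatic carbon para to a large group. The 4-chlorophenyl group is also not separated from pyridin-4-yl, with a 1.4-fold lower number from compound 2 to compound 4 (0.14 log units; within the scatter) on that exchange, whereas the exchange from pyridin-2-yl gives a 4.2-fold lower number from compound 1 to compound 4 (0.62 log units; beyond the scatter) and stands beyond the scatter. Nothing available explains these numbers.

Going by these compounds, whether a methoxy group, an amine or a carboxylic acid at this place would give a step beyond the scatter remains open. On these data alone, all four numbers also come from one cell line, and whether their order holds in other cells remains open.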